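Chloro substitution on the chromone-thiocarbamate series

A few compounds are considered here, and "the series" means these few. Any claim that something is new, unique, unknown or untested is made for them only; others in the source may bear on it.

Of the compounds shown here, three have been measured in a functional assay on MDA-MB-435S cells (Homo sapiens) for antiproliferative activity, read by MTT assay, with a stated time of 72 h; on this read-out higher numbers stand for weaker inhibition and lower numbers for stronger inhibition. Compound 1 `O=c1c(SC(=S)N2CCCCC2)coc2ccccc12` gives 17400 nM. Compound 2 `O=c1cc(CSC(=S)N2CCCCC2)oc2ccccc12` reaches only the limit of the assay, > 25000 nM, and no number. Compound 3 `O=c1c(Cl)c(CSC(=S)N2CCCCC2)oc2ccccc12` gives 770 nM. Among the compounds with values here, the one measured single-point step is an at least 32-fold lower number from compound 2 to compound 3 (1.51 log units; beyond the scatter), the change being (chloro in place of hydrogen on an aromatic carbon). Since compound 2 sits at the limit of > 25000 nM in this assay, at which 1 of the 3 values shown sits, the true size of that step is not known beyond its lower bound. How the core of compound 1 differs from that of compound 2 is not broken down here. Among the measured compounds, compound 1 has the highest number, with compound 3 the nearest to it.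

Compound 4 `O=c1c(SC(=S)N2CCCCC2)coc2ccc(Cl)cc12` is not yet measured. It differs from compound 1 by chloro in place of hydrogen on an aromatic carbon. This is the same kind of change as that from compound 2 to compound 3, but not the same: in compound 3 the chloro enters a six-membered aromatic ring with one oxygen, ortho to a group of one heavy atom and ortho to a large group, two atoms from the ring oxygen, whereas in compound 4 it enters a six-membered aromatic ring of carbon only, meta and para to a fused ring. Within the data shown here, the large step seen from compound 2 to compound 3 therefore cannot be carried over directly; only a modest gain is expected, a 2.5-fold lower number from compound 1 to compound 4 (0.40 log units; beyond the scatter), since the only evidence for chloro comes from a different place. Compound 4 is estimated at 7000 nM in this assay, expected to fall between 2000 nM and 22000 nM.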

Compound 4, half-maximal inhibitory concentration: 13300 nM
Beside the measured number, compound 4's estimate is 1.9-fold (0.28 log units) below it; the measured number falls inside the stated range.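

In this assay, chloro in place of hydrogen on an aromatic carbon of the six-membered aromatic ring of carbon only, in the core of compound 1, gives a 1.3-fold lower number from compound 1 to compound 4 (0.12 log units; within the scatter), so no gain can be read from this change at this place. Set beside the earlier step, the same kind of change does not carry over at a similar size from one core to the other: the same change on two cores in this assay, an at least 32-fold lower number (1.51 log units; beyond the scatter) from compound 2 to compound 3 and a 1.3-fold lower number (0.12 log units; within the scatter) from compound 1 to compound 4, at least 24-fold (1.39 log units) apart, beyond the scatter of two such steps

This does not show what separates the two results, since the cores differ and the chloro also enters a different ring in each case, so the effects of core and place cannot be told apart, and the earlier step is known only as a lower bound, with compound 2 standing at a limit of the assay rather than at a number: the limit of > 25000 nM in this assay, at which 1 of the 4 values shown sits.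

Open, from the compounds shown here alone, is whether chloro on the six-membered aromatic ring with one oxygen in the core of compound 1, or on the ring of carbon only in the core of compound 2, would follow the large step or the small one. Also open, going by these compounds, is whether bromo, methyl or methoxy in place of the chloro would give a step beyond the scatter on either core.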